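From Ethyl to Phenyl on a Saturated Ring Carbon

This account rests on a few compounds, and the source may have more. Where it says the series, first, only, none or still open, it means among the compounds named here.

In a functional assay on Hep 3B2 cells (Homo sapiens) for cytotoxicity, read by MTT assay, with a stated time of 6 days (on this read-out higher numbers stand for weaker inhibition and lower numbers for stronger inhibition), compound 1 `COc1ccc2c(c1)OCC(=O)N2Cc1cn(Cc2ccccc2)nn1` gives 9200 nM as a measured number. Compound 2 `CCC1Oc2ccccc2N(Cc2cn(Cc3ccccc3)nn2)C1=O` shows > 100000 nM here, which is a limit of the assay and not a number. Compound 3 `O=C1C(c2ccccc2)Oc2ccccc2N1Cc1cn(Cc2ccccc2)nn1` differs from compound 2 in one place, with phenyl in place of ethyl on a saturated ring carbon next to the ring oxygen. For the measured compounds named here, no measured step in this assay tests this change, so the expectation remains loose. Going by the values given here, it leans on compound 1 at 9200 nM as the only number available, which shows that a compound of this kind can give a reading. A move toward stronger inhibition is expected, with an estimated size of an at least 3.3-fold lower number from compound 2 to compound 3 (0.52 log units; beyond the scatter) and a real chance of another limit. In this assay the value expected for compound 3 is 30000 nM within an estimated range from 6000 nM to 100000 nM.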

Compound 3, half-maximal inhibitory concentration: > 100000 nM
Compound 3: a limit, no number; the forecaster's own chance of this, stated with the estimate: 40%; at least 3.3-fold (0.52 log units) between middle value and limit.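

In this assay compound 3 gives > 100000 nM, a limit of the assay and not a number. Compound 2 also stands at a limit, and no step can be read between compound 2 and compound 3. As far as these compounds go, whether phenyl in place of ethyl changes inhibition remains open.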